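The compounds below may be only part of what the source reports. "The series", "measured", "known", "first", "only" and "open" are said of these compounds alone.

Measured so far:
- compound 1, `COc1cc(-c2cc(/C=C/C(=O)c3ccc(Cl)c(Cl)c3)[nH]n2)cc(OC)c1OC`: 105%
- compound 2, `COc1ccc(-c2cc(/C=C/C(=O)c3ccc(N)cc3)[nH]n2)cc1OC`: 89%
- compound 3, `COc1ccc(-c2cc(/C=C/C(=O)c3cc(OC)c(OC)c(OC)c3)[nH]n2)cc1OC`: 86%

All three were run in a functional assay on MCF7 cells (Homo sapiens) for cytotoxicity, read by sulforhodamine B assay, with a stated time of 48 h, tested at 0.1 uM; on this read-out lower numbers stand for a stronger effect and higher numbers for a weaker effect at the one concentration tested. Compound 1 stands at the top of the three numbers and thus shows the weakest effect of the set; its gap to compound 2 and its gap to compound 3 both lie beyond the usual scatter of repeated runs. Compounds 2 and 3 lie within the scatter of each other, so no order is claimed between them. None of the three reaches a strong effect at this concentration.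

The next compound, compound 4, `COc1ccc(C(=O)/C=C/c2cc(-c3cc(OC)c(OC)c(OC)c3)n[nH]2)cc1OC`, keeps the shared core of compound 1 and differs from it at one place:

3,4-dimethoxyphenyl in place of 3,4-dichlorophenyl on a carbonyl carbon

The group that enters is the same one that stands on the shared core of compounds 2 and 3, though there it sits on the other side of the core rather than on the carbonyl carbon. Going by the values given here, no measured pair that isolates this particular change exists in the set, so any expectation rests on the whole series sitting near the top of the scale.

The expected step from compound 1 to compound 4 in this assay is a number 10 percentage points lower from compound 1 to compound 4 (within the scatter), a modest move toward a stronger effect that may well not exceed the scatter. Compound 4 is estimated at 95%, in the range 80% to 108%.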

Compound 4, a percentage reported as activity, at one concentration (the size of the read-out at that concentration, not a potency): 91%
Compound 4: the middle estimate sits 4 percentage points above what was measured; the measured number falls inside the stated range.
By their numbers in this assay, from the lowest: compounds 3, 2 and 4 (each within the scatter of the next); then compound 1.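

In this assay, going by these compounds alone, 3,4-dimethoxyphenyl in place of 3,4-dichlorophenyl on a carbonyl carbon gives a number 14 percentage points lower from compound 1 to compound 4 (beyond the scatter) and is the first change that can be read at a single place. It shows that the number at this position responds to the group on the carbonyl carbon, although compound 4 at 91% still shows no strong effect at the one concentration tested. The entering group carries 2 hydrogen-bond acceptors where the leaving group carries 0, but nothing available ties that difference to the step, and no supporting data bear on its cause.

The compounds shown leave open whether the step tracks the loss of the chlorine atoms or the arrival of the methoxy groups, and whether a phenyl bearing a trifluoromethyl or a carboxylic acid on the same carbonyl carbon would move the number further. With a single concentration, they also leave open whether the step would hold at other concentrations.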